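Removing one methoxy group on a chalcone-pyrazole series

The source may hold more compounds than are shown below. What is called first, only, known or untested is meant among the compounds shown, and "the series" means these compounds.

Measured so far in a functional assay on NCI-H460 cells (Homo sapiens) for inhibition, read by sulforhodamine B assay, with a stated time of 48 h; a higher number here means a weaker inhibitor of growth, a lower number a stronger inhibitor of growth:
compound 1 `COc1cc(-c2cc(/C=C/C(=O)c3ccc(N)cc3)[nH]n2)cc(OC)c1OC`: 1800 nM
compound 2 `COc1ccc(C(=O)/C=C/c2cc(-c3cc(OC)c(OC)c(OC)c3)n[nH]2)cc1OC`: 1410 nM
compound 3 `COc1ccc(C(=O)/C=C/c2cc(-c3cc(OC)c(OC)c(OC)c3)n[nH]2)cc1`: 1720 nM

Compound 1 and compound 2 differ in their cores by 4-aminophenyl in place of 3,4-dimethoxyphenyl on a carbonyl carbon, and the step of a 1.3-fold lower number from compound 1 to compound 2 (0.11 log units; within the scatter) is small. Compound 3 differs from compound 2 by hydrogen in place of methoxy on an aromatic carbon; the measured step of a 1.2-fold higher number from compound 2 to compound 3 (0.09 log units; within the scatter) lies within the scatter. Compound 4 `COc1ccc(-c2cc(/C=C/C(=O)c3ccc(N)cc3)[nH]n2)cc1OC`, not yet measured, differs from compound 1 by hydrogen in place of methoxy on an aromatic carbon. This is the same kind of change as that from compound 2 to compound 3, though here the place is also meta to a methoxy group. Resting on the step of a 1.2-fold higher number from compound 2 to compound 3 (0.09 log units; within the scatter), the expected step is a 1.1-fold higher number from compound 1 to compound 4 (0.05 log units; within the scatter). Compound 4 is therefore estimated at 2000 nM, with a likely range from 1000 nM to 4000 nM.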

Compound 4, concentration for 50% growth inhibition: 2030 nM
For compound 4 the middle estimate is 1.0-fold (0.01 log units) below the measured one; low and high end bracket the measured number.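

In this assay, hydrogen in place of methoxy on an aromatic carbon of the core of compound 1 gives a 1.1-fold higher number from compound 1 to compound 4 (0.05 log units; within the scatter). Set beside the earlier case of this change, the two steps agree: the same change on two cores in this assay, a 1.2-fold higher number (0.09 log units; within the scatter) from compound 2 to compound 3 and a 1.1-fold higher number (0.05 log units; within the scatter) from compound 1 to compound 4, 1.1-fold (0.03 log units) apart, within the scatter of two such steps. For the compounds shown here, this shows that, across these two cores, the change left the number within the scatter both times; it does not show that the same would hold on any other core, and with only two steps, neither beyond the scatter, it gives no size of effect to carry over.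

The compounds shown leave open whether a hydroxyl group, an ethoxy group or an amine in place of that methoxy would shift the number beyond the scatter. Also open, as far as these compounds go, is what removing more than one methoxy group would do.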